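Adding a 4-chlorophenyl to the amide of compound 2

The source may report more compounds than this note shows. Statements on the series, on what has been measured and on what is new or still open speak of the compounds shown alone.

Of the compounds shown here, three that share a thiourea-bearing core have been measured in a functional assay on BT-549 cells (Homo sapiens) for inhibition, read by sulforhodamine B assay, with a stated time of 48 h; a higher number here means a weaker inhibitor of growth, a lower number a stronger inhibitor of growth. Compound 1 `O=CN1CCN(c2ccc(Cl)cc2)C1=S` gives 25400 nM. Compound 2 `N#C/C(=C\N1CCN(C(=O)c2ccco2)C1=S)C(N)=O` gives 22500 nM. Compound 3 `COc1cc(C(=O)N2CCN(C=O)C2=S)cc(OC)c1OC` gives 25000 nM. Compound 2 carries the lowest of the three numbers, but its gap to compound 3 and its gap to compound 1 both fall within the usual scatter of the measurement, so no order among the three can be read from these values.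

The step under consideration leads from compound 2 to compound 4 `N#C/C(=C\N1CCN(C(=O)c2ccco2)C1=S)C(=O)Nc1ccc(Cl)cc1`, which has not yet been measured in this assay. The structural change is 4-chlorophenyl in place of hydrogen on an amide-type nitrogen. Among the compounds with values here, no pair of measured compounds differs in this way, so there is no measured step to lean on, and the three values seen so far lie close together at the weaker end.

On that basis the author expects compound 4 to show a small step toward a lower number, possibly no larger than the scatter, amounting to a 1.5-fold lower number from compound 2 to compound 4 (0.18 log units; within the scatter). For compound 4 the estimate in this assay is 15000 nM, with a range from 4000 nM to 60000 nM.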

Compound 4, concentration for 50% growth inhibition: 8600 nM
For compound 4 the middle estimate is 1.7-fold (0.24 log units) above the measured one; the measured number falls inside the stated range.
By their numbers in this assay, from the lowest: compound 4; then compounds 2, 3 and 1 (each within the scatter of the next).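

Putting 4-chlorophenyl in place of hydrogen on an amide-type nitrogen gives a 2.6-fold lower number from compound 2 to compound 4 (0.42 log units; beyond the scatter) in this assay. Within the data shown here, this is the first step that can be read at all, and its size lies beyond the scatter, whereas the three earlier compounds offered no pair differing in one place and their values could not be ordered. It shows that this nitrogen accepts a substituent as large as 4-chlorophenyl with a modest gain in growth inhibition rather than a loss, although nothing at hand accounts for the gain.

The step rests on a single pair, so it cannot separate the part played by the aromatic ring from that of the chlorine, and a plain phenyl, a 4-methoxyphenyl, a benzyl or a simple methyl on the same nitrogen could each help to tell these apart. As far as these compounds go, whether the same replacement would lower the number on a compound with something other than the furan-2-carbonyl group of compound 2 also remains open.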